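Notes on the core: isobutyl at the substituted ring carbon

This account rests on a few compounds, and the source may have more. Where it says the series, first, only, none or still open, it means among the compounds named here.

The series shares the core of compound 1 `O=C(O)COc1ccc(Cl)cc1C#Cc1cncc(S(=O)(=O)N2CCOCC2)c1`, compound 2 `CS(=O)(=O)c1cncc(C#Cc2cc(Cl)ccc2OCC(=O)O)c1` and compound 3 `O=C(O)COc1ccc(Cl)cc1C#Cc1cccnc1`, and the new member is compound 4 `CC(C)Cc1ccncc1C#Cc1cc(Cl)ccc1OCC(=O)O`. In an assay on CHO cells for displacement of a labelled ligand from prostaglandin D2 receptor 2 (Homo sapiens), read by scintillation counting (a lower number here means a stronger inhibitor, a higher number a weaker inhibitor), compound 1 gives 41 nM, compound 2 gives 60 nM and compound 3 gives 117 nM; compound 3 thus stands highest of the three, with compound 2 nearest and compound 1 furthest.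

Compound 4 differs from compound 3 by isobutyl in place of hydrogen on an aromatic carbon. Within the data shown here, the steps that bear on it are the two that fill the same aromatic carbon with a group: a 2.9-fold higher number from compound 1 to compound 3 (0.46 log units; beyond the scatter) and a 2.0-fold higher number from compound 2 to compound 3 (0.29 log units; within the scatter). Both read from the occupied carbon to the bare one, and both gave a higher number. Isobutyl is a different kind of group from either sulfonyl, so the analogy is loose, but the direction it suggests for compound 4 in this assay is a lower number, of modest size, possibly within the scatter.

The estimate for compound 4 in this assay is therefore 60 nM, within 25 nM to 150 nM; this expected step is a 2.0-fold lower number from compound 3 to compound 4 (0.29 log units; within the scatter).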

Compound 4, inhibition constant: 4.9 nM
Compound 4: middle estimate off by 12-fold (1.09 log units), on the high side, and the stated range ends above it.
By their numbers in this assay, from the lowest: compound 4; then compounds 1, 2 and 3 (each within the scatter of the next, the first and the last beyond it).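

In this assay, isobutyl on the aromatic carbon ortho to a large group and opposite the ring nitrogen gives a 24-fold lower number from compound 3 to compound 4 (1.38 log units; beyond the scatter) and so makes a far larger difference than either sulfonyl group did on the core, where the steps to the unsubstituted ring were modest or within the scatter. The entering group has no ring, no hydrogen-bond donors or acceptors and no net charge, so a large drop in the number at this carbon requires none of these features. No measurement shown here accounts for the size of this step.

Among these compounds, the series holds only one group at this carbon, so it remains open how a methyl, a longer chain, a cyclopropyl ring or an amine there would read. Also open, from the compounds shown here alone, is whether isobutyl and methylsulfonyl together on the ring would add up.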